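A few compounds are considered here, and "the series" means these few. Any claim that something is new, unique, unknown or untested is made for them only; others in the source may bear on it.

For the measured compounds named here, compound 1 `Cn1ccc(-c2cn3nccc3c(-c3cnn([C@]4(CC#N)C[C@@H](C#N)C4)c3)n2)n1` is one of only two compounds so far measured in an ADME assay on MDCK-II cells (Canis lupus familiaris) for permeability; a higher number here means that the compound crosses the layer faster, a lower number that the compound crosses the layer more slowly. In this assay compound 1 gives 20 10^-6 cm/s, and compound 2 `CCN1CC(CC#N)(n2cc(-c3nc(-c4cnn(C)c4)cn4nccc34)cn2)C1` gives 33 10^-6 cm/s, a result that lies within the scatter of the first, so the two stand side by side rather than in any order. Compound 3 `N#CC[C@]1(n2cc(-c3nc(-c4cc[nH]n4)cn4nccc34)cn2)C[C@H](C#N)C1` remains unmeasured. It differs from compound 1 in a single place: hydrogen in place of methyl on an aromatic nitrogen. Going by the values given here, no measured pair shows this same change, so its effect is uncertain; a modest downward step a 1.7-fold lower number from compound 1 to compound 3 (0.22 log units; within the scatter) is expected, though one no larger than the scatter would not surprise. Compound 3 is therefore estimated at 12 10^-6 cm/s, within a range from 5 10^-6 cm/s to 25 10^-6 cm/s.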

Compound 3, apparent permeability in the MDCK-II assay: 17 10^-6 cm/s
Estimate against measurement, compound 3: 1.4-fold (0.15 log units) below, and the stated range covers the measured number.
By their numbers in the MDCK-II assay, from the lowest: compounds 3, 1 and 2 (each within the scatter of the next).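

For the compounds shown here, in the MDCK-II assay the first pair to carry this change, 1-methyl-1H-pyrazol-3-yl to 1H-pyrazol-3-yl, gives a 1.2-fold lower number from compound 1 to compound 3 (0.07 log units; within the scatter) and so shows that hydrogen and methyl on this aromatic nitrogen read alike here. In a physicochemical assay for lipophilicity, using the shake flask method, in phosphate buffer, measured as octanol-water partition, at pH 7.4 (a higher number here means a more lipophilic compound, a lower number a more polar compound), compound 1 gives 1.6 and compound 3 gives 1.7 with a number 0.10 log units higher from compound 1 to compound 3 (within the scatter) as the step, so the two also read alike there. Nothing available accounts for this. From the compounds shown here alone, whether an ethyl group or a longer chain ending in an amine on this nitrogen would read alike remains open.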